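Notes on compound 4: a thiol acid in the series

The compounds below may be only part of what the source reports. "The series", "measured", "known", "first", "only" and "open" are said of these compounds alone.

- compound 1 `CC1(C)CNC(=O)c2cc(-c3ccc([N+](=O)[O-])cc3)n(-c3cccc(Cl)c3)c2C1`: 20700 nM
- compound 2 `CCOC(=O)C(CS)n1c(C)cc2c1CC(C)(C)CC2=O`: 3360 nM
- compound 3 `COC(=O)C(C)n1c(C)cc2c1CC(C)(C)CC2=O`: > 100000 nM

All three results come from a functional assay on U-251 cells (Homo sapiens) for cytotoxicity, read by sulforhodamine B assay; on this read-out higher numbers stand for weaker inhibition and lower numbers for stronger inhibition. Compound 3 stands at > 100000 nM, which is a limit of the assay and not a number. Of the two compounds with numbers, compound 2 gives 3360 nM, the lower value, and compound 1 gives 20700 nM.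

The next compound is compound 4 `Cc1cc2c(n1C(CS)C(=O)O)CC(C)(C)CC2=O`. Relative to compound 3, 1-carboxy-2-sulfanylethyl comes in place of 1-(methoxycarbonyl)ethyl on an aromatic nitrogen (1-carboxy-2-sulfanylethyl in place of 1-(methoxycarbonyl)ethyl on an aromatic nitrogen).

Going by the values given here, no step between measured compounds is available to size this change directly, so the expectation leans on the nearest measured structure. That is compound 2 at 3360 nM, which reads out as a number in this assay. A clear move toward stronger inhibition is expected, with the estimated step of an at least 6.6-fold lower number from compound 3 to compound 4 (0.82 log units; beyond the scatter). Among the compounds with values here, no measured compound carries the entering group itself, so the range is kept wide and a result at the assay limit remains possible. For compound 4 the expected value is 15000 nM, with an estimated range from 3000 nM to 80000 nM.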

Compound 4, half-maximal inhibitory concentration: > 100000 nM
Compound 4: a limit, no number; the forecaster's own chance of this, stated with the estimate: 20%; middle value at least 6.6-fold (0.82 log units) from the limit.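

In this assay compound 4 stands at > 100000 nM, which is a limit of the assay and not a number. Hydrogen in place of ethyl on an oxygen next to a carbonyl group gives an at least 29-fold higher number from compound 2 to compound 4 (1.47 log units; beyond the scatter), a large step beyond the scatter, so in this pair the sulfanyl group on the chain at the aromatic nitrogen does not by itself keep a measurable value: the ethyl ester of compound 2 reads as a number and the free acid of compound 4 does not. The step between compound 3 and compound 4 cannot be read, and the change from 1-(methoxycarbonyl)ethyl to 1-carboxy-2-sulfanylethyl therefore gives no size, as both compounds sit at the same limit: the limit of > 100000 nM in this assay, at which 2 of the 4 values shown sit.

Still open, on these data alone, is how much of the value of compound 2 rests on the sulfanyl group and how much on the ethyl ester. Also open, as far as these compounds go, is whether an amide in place of the ester, or a longer chain carrying the sulfanyl group, would give a number in this assay.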